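Working notes: a hydroxy addition to compound 1

A few compounds are considered here, and "the series" means these few. Any claim that something is new, unique, unknown or untested is made for them only; others in the source may bear on it.

Measured so far:
- compound 1 `C=CC[C@H]1C[C@]2([C@@H](C)Cc3ccc(OC)cc3)OCOC2=CC1=O`: 20 nM
- compound 2 `C=CC[C@H]1C[C@]2([C@@H](C)Cc3cccc(OC)c3)OCOC2=CC1=O`: 8800 nM
- compound 3 `C=CC[C@H]1C[C@]2([C@@H](C)Cc3ccccc3)OCOC2=CC1=O`: 5100 nM

In a functional assay on M14 cells (Homo sapiens) for antiproliferative activity, with a stated time of 72 h (a higher number here means a weaker inhibitor, a lower number a stronger inhibitor), compound 1 holds the lowest of the three numbers, and its steps to both others lie beyond the scatter. Compound 4 `C=CC[C@H]1C[C@]2([C@@H](C)Cc3ccc(OC)c(O)c3)OCOC2=CC1=O` keeps the methoxy of compound 1 and adds hydroxy in place of hydrogen on an aromatic carbon, ortho to a methoxy group and meta to a large group: hydroxy in place of hydrogen on an aromatic carbon.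

Going by the values given here, three measured steps bear on this. Hydrogen in place of methoxy gives a 260-fold higher number from compound 1 to compound 3 (2.41 log units; beyond the scatter), and 3-methoxyphenyl in place of 4-methoxyphenyl gives a 440-fold higher number from compound 1 to compound 2 (2.64 log units; beyond the scatter), both large. Hydrogen in place of methoxy gives a 1.7-fold lower number from compound 2 to compound 3 (0.24 log units; within the scatter), within the scatter. Among the compounds with values here, none of these adds a group to the aromatic ring while keeping the methoxy of compound 1, so the data hold no direct precedent for this change.

The methoxy whose removal gave a 260-fold higher number from compound 1 to compound 3 (2.41 log units; beyond the scatter) remains in compound 4, so a loss of that size is not expected. A moderate move to a higher number remains the more likely outcome, and the expected step is a 5.0-fold higher number from compound 1 to compound 4 (0.70 log units; beyond the scatter). For compound 4 the estimated value is 100 nM, with an expected range of 20 nM to 1000 nM.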

Compound 4, half-maximal inhibitory concentration: 8 nM
The estimate for compound 4 lay 13-fold (1.10 log units) above the measured number, outside the stated range (below it).
By their numbers in this assay, from the lowest: compound 4; then compound 1; then compounds 3 and 2 (each within the scatter of the next).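

In this assay, hydroxy in place of hydrogen on an aromatic carbon, ortho to a methoxy group and meta to a large group, gives a 2.5-fold lower number from compound 1 to compound 4 (0.40 log units; beyond the scatter); this modest step shows that the position accepts an added group while the methoxy of compound 1 stays in place, with no loss in this read-out. The earlier steps shown here only removed or moved that methoxy, whereas compound 4 adds to the ring and shows that the substitution pattern of compound 1 can be extended here with a move towards a lower number. No measured property accompanies this step, so the data give no account of what lies behind it.

The compounds shown leave open whether the lower number is specific to hydroxy or would also appear with an amine, a fluorine atom or a carboxylic acid on this carbon. They also leave open whether the hydroxy would have the same effect in a compound lacking the methoxy of compound 1, or with a longer chain, such as ethoxy, in place of that methoxy.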